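The source may report more compounds than this note shows. Statements on the series, on what has been measured and on what is new or still open speak of the compounds shown alone.

Compounds measured so far:
- compound 1 `CCN(CC)S(=O)(=O)c1ccc(S(=O)(=O)N2CCC[C@@H](C(=O)N3CCC(O)CC3)C2)cc1`, in a functional assay on BXPC-3 cells (Homo sapiens) for inhibition, read by MTT assay, with a stated time of 7 days (on this read-out lower numbers stand for stronger inhibition and higher numbers for weaker inhibition), compound 1 gives 4710 nM.
- compound 2 `CCN(CC)S(=O)(=O)c1ccc(S(=O)(=O)N2CCC[C@@H](C(=O)N3CCC(C(F)(F)F)CC3)C2)cc1`, in this assay compound 2 gives 370 nM.
- compound 3 `CN(C)S(=O)(=O)c1ccc(S(=O)(=O)N2CCC[C@@H](C(=O)N3CCC(F)(F)CC3)C2)cc1`, in this assay compound 3 gives 560 nM.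

Compound 3 sits second highest of these three numbers. Its nearest neighbour is compound 2, whose number is within the scatter of that of compound 3, so no order between the two can be read. Compound 1 stands well apart, with the highest number of the three.

Compound 4 `CCN(CC)S(=O)(=O)c1ccc(S(=O)(=O)N2CCC[C@@H](C(=O)N3CCC(F)(F)CC3)C2)cc1` differs from compound 3 in one place: diethylamino in place of dimethylamino on a sulfonyl sulfur. Going by the values given here, the one step measured between two compounds that differ in a single place, a 13-fold lower number from compound 1 to compound 2 (1.10 log units; beyond the scatter), concerns a different part of the molecule and says nothing about this exchange. Compounds 2 and 3 carry the two amino groups in question, but they also differ in the saturated ring, so their closeness tells little on its own. Among the compounds with values here, with no measured step bearing on the change, the expectation for compound 4 in this assay is a step of a 1.1-fold lower number from compound 3 to compound 4 (0.05 log units; within the scatter), that is, none beyond the scatter. Compound 4 is therefore estimated at 500 nM, with a range from 220 nM to 1200 nM.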

Compound 4, half-maximal inhibitory concentration: 120 nM
Compound 4: the middle estimate sits 4.2-fold (0.62 log units) above what was measured, outside the stated range (below it).
By their numbers in this assay, from the lowest: compound 4; then compounds 2 and 3 (each within the scatter of the next); then compound 1.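

In this assay, diethylamino in place of dimethylamino on a sulfonyl sulfur gives a 4.7-fold lower number from compound 3 to compound 4 (0.67 log units; beyond the scatter), so this position, which the earlier single-place step did not touch, clearly affects the read-out. With diethylamino kept, the group on the carbonyl carbon matters too: 4,4-difluoropiperidin-1-yl in place of 4-(trifluoromethyl)piperidin-1-yl gives a 3.1-fold lower number from compound 2 to compound 4 (0.49 log units; beyond the scatter), and in place of 4-hydroxypiperidin-1-yl it gives a 39-fold lower number from compound 1 to compound 4 (1.59 log units; beyond the scatter). No measurement at hand explains why these changes act as they do.

Going by these compounds, whether the trend continues with a longer chain on the sulfonyl sulfur, such as dipropylamino, or reverses with a ring there, such as piperidin-1-yl, remains open. On these data alone, the exchange of dimethylamino for diethylamino is also read only with 4,4-difluoropiperidin-1-yl on the carbonyl carbon, so its size with other groups there is unknown.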